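Swapping a carbamate for an anilino group on a shared core

The source may report more compounds than this note shows. Statements on the series, on what has been measured and on what is new or still open speak of the compounds shown alone.

Within the data shown here, compound 2 `COC(=O)Nc1nc2ccc(NC(=O)c3c(Cl)cccc3Cl)cc2s1` is the one compound of the pair for which a functional assay on WI-38 VA13 cells (Homo sapiens) for cytotoxicity (a higher number here means that more compound is needed for the effect, a lower number that less compound is needed), gives a number: in this assay compound 2 gives 0.0095 ug/mL. Compound 1 `O=C(Nc1ccc2nc(NC(=O)C3CCCCC3)sc2c1)c1ccc(Cl)cc1Cl` reaches only a limit, giving > 4 ug/mL in this assay, which is the limit of > 4 ug/mL in this assay, at which 1 of the 2 values shown sits. Compound 3 `COc1ccccc1Nc1nc2ccc(NC(=O)c3c(Cl)cccc3Cl)cc2s1` has not been measured; it differs from compound 2 by 2-methoxyphenyl in place of methoxycarbonyl on a nitrogen on an aromatic ring. Among the measured compounds shown here, no step between measured compounds is available to guide the size of this change, so an estimate rests on the structures alone. A loss beyond the scatter is expected, with the estimated step of a 32-fold higher number from compound 2 to compound 3 (1.50 log units; beyond the scatter), putting compound 3 at an expected 0.3 ug/mL, between 0.03 ug/mL and 4 ug/mL.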

Compound 3, half-maximal effective concentration: > 7.2 ug/mL
Compound 3: a limit, no number; the forecaster's own chance of this, stated with the estimate: 25%; at least 24-fold (1.38 log units) between middle value and limit.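

Among these compounds, this is the first step in which only this position changes: with 2-methoxyphenyl in place of methoxycarbonyl on the nitrogen, this assay shows an at least 750-fold higher number from compound 2 to compound 3 (2.87 log units; beyond the scatter). The low number of compound 2 therefore depends on what sits on this nitrogen, and an anilino group does not keep it. Compound 3 stands at a limit, not a number: the limit of > 7.2 ug/mL in this assay, at which 1 of the 3 values shown sits.

The step removes the carbonyl and adds an aromatic ring at once, so the compounds shown do not separate the two. From the compounds shown here alone, how a free amine or an acetyl group on this nitrogen would read remains open.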